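Amide nitrogen substituents on the shared core

The source may report more compounds than this note shows. Statements on the series, on what has been measured and on what is new or still open speak of the compounds shown alone.

Among the measured compounds shown here, compound 1 `O=C(CCC(=O)OCCCCCCSc1ccc([N+](=O)[O-])c2nonc12)Nc1ccccc1Cl` gives 2950 nM in an ADME assay on HUVEC cells (Homo sapiens) for cytotoxicity, read by MTT assay, with a stated time of 72 h (on this read-out higher numbers stand for weaker inhibition and lower numbers for stronger inhibition), the highest of the three numbers measured so far. Its nearest neighbour is compound 3 `CN(C)CCCNC(=O)CCC(=O)OCCCCCCSc1ccc([N+](=O)[O-])c2nonc12`, which in this assay gives 1600 nM, and the furthest is compound 2 `COc1ccc(NC(=O)CCC(=O)OCCCCCCSc2ccc([N+](=O)[O-])c3nonc23)cc1`, which in this assay gives 1590 nM. Both steps away from compound 1 stay within the scatter: a 1.9-fold lower number from compound 1 to compound 2 (0.27 log units; within the scatter) and a 1.8-fold lower number from compound 1 to compound 3 (0.27 log units; within the scatter). The remaining measured step is a 1.0-fold higher number from compound 2 to compound 3 (0.00 log units; within the scatter).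

Compound 4 `CN(C)CCNC(=O)CCC(=O)OCCCCCCSc1ccc([N+](=O)[O-])c2nonc12` differs from compound 1 in one place: 2-(dimethylamino)ethyl in place of 2-chlorophenyl on an amide-type nitrogen. For the measured compounds named here, the step that bears most directly on this change is the one to compound 3, where 3-(dimethylamino)propyl replaced the same 2-chlorophenyl group on the amide-type nitrogen, a 1.8-fold lower number from compound 1 to compound 3 (0.27 log units; within the scatter). The step to compound 2, a 1.9-fold lower number from compound 1 to compound 2 (0.27 log units; within the scatter), was of the same size. A small downward step, or none beyond the scatter, is therefore expected in this assay, a 1.7-fold lower number from compound 1 to compound 4 (0.24 log units; within the scatter). For compound 4 in this assay the estimate is 1700 nM, with a range of 800 nM to 3600 nM.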

Compound 4, half-maximal inhibitory concentration: 2160 nM
Compound 4: the middle estimate sits 1.3-fold (0.10 log units) below what was measured; low and high end bracket the measured number.
By their numbers in this assay, from the lowest: compounds 2, 3, 4 and 1 (each within the scatter of the next).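

In this assay, 2-(dimethylamino)ethyl on the amide-type nitrogen stays within the scatter of both aromatic groups, a 1.4-fold lower number from compound 1 to compound 4 (0.14 log units; within the scatter) and a 1.4-fold higher number from compound 2 to compound 4 (0.13 log units; within the scatter), so the ring-free amine chain of compound 4 gives no step beyond the scatter against either 2-chlorophenyl or 4-methoxyphenyl. Among the compounds shown here, compound 4 also gives the first direct reading of chain length in this amine series, and the change from 3-(dimethylamino)propyl to 2-(dimethylamino)ethyl, a 1.4-fold higher number from compound 3 to compound 4 (0.13 log units; within the scatter), likewise stays within the scatter. No available evidence accounts for how closely these compounds agree.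

Going by these compounds, it remains open whether a longer chain such as 4-(dimethylamino)butyl, a morpholine ring or a carboxylic acid at the chain end would give a step beyond the scatter. On these data alone, how these amide-nitrogen changes read on cells other than those in this assay also remains open.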